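Aryl urea change from compound 1 to compound 4

The source may hold more compounds than are shown below. What is called first, only, known or untested is meant among the compounds shown, and "the series" means these compounds.

In an assay on isolated protein for inhibition of proto-oncogene tyrosine-protein kinase receptor Ret variant V804L (Homo sapiens), read by 33P incorporation, with stated times of 15 min and 40 min (a lower number here means a stronger inhibitor, a higher number a weaker inhibitor), compound 1 `O=C(Nc1ccc(Cl)cc1)Nc1ccc(Nc2ncnc3c2OCCN3)cc1` gives > 10000 nM, which is a limit of the assay rather than a number. Compound 2 `O=C(Nc1ccc(Br)cc1)Nc1ccc(Nc2ncnc3c2OCCN3)cc1` also gives only a limit in this assay, > 10000 nM. Compound 3 `COc1ccc(NC(=O)Nc2ccc(Nc3ncnc4c3OCCN4)cc2)cc1` gives 1220 nM in this assay. The step that the two limits leave unreadable from compound 1 to compound 2 cannot be read. The steps of an at least 8.1-fold lower number from compound 1 to compound 3 (0.91 log units; beyond the scatter) and an at least 8.1-fold lower number from compound 2 to compound 3 (0.91 log units; beyond the scatter) both point the same way, toward the methoxy analogue, consistent with the limit of > 10000 nM in this assay, at which 2 of the 3 values shown sit. Compound 4 `Cc1ccc(F)c(NC(=O)Nc2ccc(Nc3ncnc4c3OCCN4)cc2)c1` has not yet been measured in this assay; it differs from compound 1 by 2-fluoro-5-methylphenyl in place of 4-chlorophenyl on an amide-type nitrogen. The measured steps replace the chloro at one place with methoxy or bromo, while the change to compound 4 moves and multiplies the substituents, so none of them bears on it directly. A step in the direction of a lower number is therefore expected, an at least 2.8-fold lower number from compound 1 to compound 4 (0.45 log units; beyond the scatter), though with wide uncertainty. For compound 4 the estimate in this assay is 3500 nM, within 700 nM to 15000 nM.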

Compound 4, half-maximal inhibitory concentration: 7000 nM
The estimate for compound 4 lay 2.0-fold (0.30 log units) below the measured number; the measured number falls inside the stated range.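

In this assay, 2-fluoro-5-methylphenyl on the amide-type nitrogen gives a readable number, so a value below the limit at this position is not confined to the 4-methoxyphenyl of compound 3, yet this group is the weaker of the two: a 5.7-fold higher number from compound 3 to compound 4 (0.76 log units; beyond the scatter). Against the two halogen compounds only floors can be stated, an at least 1.4-fold lower number from compound 1 to compound 4 (0.15 log units; that floor lies within the scatter) and an at least 1.4-fold lower number from compound 2 to compound 4 (0.15 log units; that floor lies within the scatter), so neither comparison shows a step beyond the scatter. These two comparisons stay open-ended because one side of each is a limit of the assay and not a number: the limit of > 10000 nM in this assay, at which 2 of the 4 values shown sit.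

The separate shares of the fluoro and the methyl remain unresolved; compound 4 carries both. Also open, from the compounds shown here alone, is whether an ethoxy or an amine in place of the methoxy of compound 3 would keep its lower number.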